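A few compounds are considered here, and "the series" means these few. Any claim that something is new, unique, unknown or untested is made for them only; others in the source may bear on it.

Working notes on the series. Going by the values given here, in an ADME assay on HepG2 cells (Homo sapiens) for cytotoxicity, read by luminescence, CellTiter-Glo and ATP content, with a stated time of 72 h (on this read-out higher numbers stand for an effect only at larger amounts of compound and lower numbers for an effect already at smaller amounts), compound 1 `COc1cccc(CNCCCNc2ccnc3cc(-c4ccc(F)cc4)ccc23)c1O` gives 6840 nM, and compound 2 `COc1cccc(CNCCCNc2ccnc3cc(Cc4cc(C)cc(C)c4)ccc23)c1O` gives 2680 nM; the step of a 2.6-fold lower number from compound 1 to compound 2 (0.41 log units; beyond the scatter) is the only measured step so far. On these two numbers compound 2 stands lowest, with compound 1 as its nearest neighbour at a higher number, beyond the scatter.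

Compound 3 `COc1cccc(CNCCCNc2ccnc3cc(CCc4ccccc4)ccc23)c1O` is still to be measured in this assay. It differs from compound 2 by benzyl in place of 3,5-dimethylphenyl on a saturated chain carbon bound to an aromatic carbon. Among the compounds with values here, the one step that bears on this change is the one from compound 1 to compound 2, which lowered the number modestly; compound 3 keeps the chain linking the ring to the core but drops the two methyl groups, so the structural change runs partly back toward compound 1. Within the data shown here, a step in this assay that raises the number is therefore expected, likely smaller than the one from compound 1 to compound 2 and possibly within the scatter, as a 1.5-fold higher number from compound 2 to compound 3 (0.17 log units; within the scatter). Compound 3 is accordingly estimated at 4000 nM, within a range from 2000 nM to 9000 nM.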

Compound 3, half-maximal effective concentration: 6800 nM
Estimate against measurement, compound 3: 1.7-fold (0.23 log units) below, and the stated range covers the measured number.
By their numbers in this assay, from the lowest: compound 2; then compounds 3 and 1 (each within the scatter of the next).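

In this assay, the change from 3,5-dimethylbenzyl to phenethyl gives a 2.5-fold higher number from compound 2 to compound 3 (0.40 log units; beyond the scatter), so the lower number of compound 2 does not carry over to every ring held on a saturated chain. Phenethyl in place of 4-fluorophenyl on an aromatic carbon gives a 1.0-fold lower number from compound 1 to compound 3 (0.00 log units; within the scatter), so compound 3 goes against any reading that a chain alone lowers the number, and among these three compounds only compound 2 stands apart. Nothing at hand speaks to what lies behind these steps.

Compound 2 and compound 3 differ in both chain length and the two methyl groups, and these compounds do not separate the two; an unsubstituted benzyl or a 3,5-dimethylphenethyl would. On these data alone, how an amine or a carboxylic acid on the ring, or a longer chain, would read here also remains open.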